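The compounds below may be only part of what the source reports. "The series", "measured", "known", "first", "only" and "open" are said of these compounds alone.

Compound 3 `COc1ccc(F)cc1-c1cccc(-c2nn(CCO)c(=O)o2)c1` gives 69% in a functional assay on the whole organism (strain Wistar albino) for inhibition, with Rattus norvegicus as the target, read by paw edema, with stated times of 30 min and 2 h, at a dose of 10 mg/kg by the oral route; on this read-out higher numbers stand for more inhibition at the one dose given (going by the name of the read-out) and lower numbers for less inhibition; it stands second highest of the three measured numbers. Compound 1 `COc1ccc(F)cc1-c1cccc(-c2nn(CCCC#N)c(=O)o2)c1`, which gives 71%, lies within the scatter of compound 3; compound 2 `COc1ccc(F)cc1-c1cccc(-c2n[nH]c(=O)o2)c1`, which gives 56%, lies beyond that scatter. Compound 4 `COC(=O)CCCn1nc(-c2cccc(-c3cc(F)ccc3OC)c2)oc1=O` differs from compound 3 by (methoxycarbonyl)methyl in place of hydroxy on a saturated chain carbon, two bonds along the chain from an aromatic nitrogen. The measured step that bears on this is a number 2 percentage points lower from compound 1 to compound 3 (within the scatter), where one group at the end of the chain replaced another without a shift beyond the scatter; by contrast a number 15 percentage points lower from compound 1 to compound 2 (beyond the scatter) and a number 13 percentage points higher from compound 2 to compound 3 (beyond the scatter) concern the substituent on the aromatic nitrogen itself, which compound 4 keeps. Compound 4 is therefore expected to show no step beyond the scatter, a number 1 percentage points lower from compound 3 to compound 4 (within the scatter). Compound 4 is estimated at 68% with a range of 57% to 78%.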

Compound 4, a percentage reported as inhibition, in the whole organism at one dose (the size of the read-out at that dose, not a potency): 74%
Estimate against measurement, compound 4: 6 percentage points below; the range from low to high includes it.
By their numbers in this assay, from the lowest: compound 2; then compounds 3, 1 and 4 (each within the scatter of the next).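

In this assay, a hydroxy, a nitrile and a methoxycarbonyl at the chain end all read alike, with a number 5 percentage points higher from compound 3 to compound 4 (within the scatter) for (methoxycarbonyl)methyl in place of hydroxy and a number 3 percentage points higher from compound 1 to compound 4 (within the scatter) for methoxycarbonyl in place of cyano. The ester-bearing chain also separates from the bare ring nitrogen, with a number 18 percentage points higher from compound 2 to compound 4 (beyond the scatter) for 3-(methoxycarbonyl)propyl in place of hydrogen. Nothing available explains these numbers. The compounds shown leave open whether a carboxylic acid or an amine at the chain end would read the same, and whether a longer chain would hold the effect.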